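The source may hold more compounds than are shown below. What is called first, only, known or untested is meant among the compounds shown, and "the series" means these compounds.

Among the measured compounds shown here, in a functional assay on NCI-H1581 cells (Homo sapiens) for antiproliferative activity, read by CCK-8 assay, with a stated time of 72 h (a lower number here means a stronger inhibitor, a higher number a weaker inhibitor), compound 1 (`CCN1CCN(c2ccc(C(=O)Nc3n[nH]c4nc(-c5c(Cl)c(OC)cc(OC)c5Cl)ccc34)cc2)CC1`) gives 0.7 nM as the lowest number so far. Compound 2 (`COc1cc(OC)c(Cl)c(-c2ccc3c(NC(=O)c4cnc(N5CCN(C)CC5)cn4)n[nH]c3n2)c1Cl`) gives 60.6 nM and so lies beyond the usual scatter from compound 1, on the weaker side.

Compound 3 (`COc1cc(OC)c(Cl)c(-c2ccc3c(NC(=O)c4ccccc4)n[nH]c3n2)c1Cl`) is compound 1 with hydrogen in place of 4-ethylpiperazin-1-yl on an aromatic carbon. For the measured compounds named here, no measured pair shows this change alone, so the data give no direct guide. Still, compound 2 at 60.6 nM shows that a structure departing from compound 1 can land far higher, and this change removes a large group outright. A clear loss of potency in this assay is therefore expected, with much uncertainty about its size. The expected rise is a 110-fold higher number from compound 1 to compound 3 (2.06 log units; beyond the scatter) as an estimate, well beyond the scatter. The estimated value for compound 3 is 80 nM with 15 nM to 450 nM as the expected range.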

Compound 3, half-maximal inhibitory concentration: > 1000 nM
Compound 3 ended at the assay's limit; the forecaster's own chance of this, stated with the estimate: 5%; middle value at least 12-fold (1.09 log units) away from the limit.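

In this assay, among the compounds shown here, replacing the 4-ethylpiperazin-1-yl group with hydrogen on this aromatic carbon gives an at least 1400-fold higher number from compound 1 to compound 3 (3.15 log units; beyond the scatter), the first direct reading of what this group contributes. The potency of compound 1 therefore does not survive on the shared core and unsubstituted ring alone; in this pair, it depends on the 4-ethylpiperazin-1-yl group at this position. The result for compound 3 is a limit of the assay and not a number, so the step gives only the smallest possible size of the loss: the limit of > 1000 nM in this assay, at which 1 of the 3 values shown sits.

As far as these compounds go, compound 3 loses the whole group at once, so it remains open whether the ring, its nitrogens or the ethyl group carries the effect. A morpholine ring, a dimethylamino group or an unsubstituted piperazine at the same position would help to separate these parts.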